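A Cyclic Ether Replaces the Open Ethoxy Chain

The source may hold more compounds than are shown below. What is called first, only, known or untested is meant among the compounds shown, and "the series" means these compounds.

For the measured compounds named here, compound 2 `CCO[C@@H](C)CN1CCC[C@H](Cn2c(-c3cccnc3C)nc3cn(-c4cccc(OC)c4)nc3c2=O)C1` gives 5 nM in an assay on HEK293 cells for displacement of a labelled ligand from growth hormone secretagogue receptor type 1 (Homo sapiens), with a stated time of 60 min (a higher number here means a weaker inhibitor, a lower number a stronger inhibitor), the higher of the two numbers so far, while compound 1 `COc1cccc(-n2cc3nc(-c4cccnc4C)n(C[C@H]4CCCN(CC5CCC5)C4)c(=O)c3n2)c1` gives 1.6 nM. Going by the values given here, the one step between them, a 3.1-fold higher number from compound 1 to compound 2 (0.49 log units; beyond the scatter), exchanged cyclobutyl for 1-ethoxyethyl. Compound 3 `COc1cccc(-n2cc3nc(-c4cccnc4C)n(C[C@H]4CCCN(CC5CCOC5)C4)c(=O)c3n2)c1` carries the change (oxolan-3-yl in place of 1-ethoxyethyl on a saturated chain carbon bound to an amine nitrogen in a ring), which puts a ring back at that position. Only a 3.1-fold higher number from compound 1 to compound 2 (0.49 log units; beyond the scatter) bears on this, and it was modest. For compound 3 a modest step back toward compound 1 is expected, a 2.0-fold lower number from compound 2 to compound 3 (0.30 log units; within the scatter). Compound 3 is therefore estimated at 2.5 nM, with a range of 1 nM to 6 nM.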

Compound 3, half-maximal inhibitory concentration: 60 nM
Beside the measured number, compound 3's estimate is 24-fold (1.38 log units) below it, outside the stated range (above it).
By their numbers in this assay, from the lowest: compound 1; then compound 2; then compound 3.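

In this assay, the position on a saturated chain carbon bound to an amine nitrogen in a ring proved sensitive to the exchange for oxolan-3-yl, with a 12-fold higher number from compound 2 to compound 3 (1.08 log units; beyond the scatter) and a 38-fold higher number from compound 1 to compound 3 (1.57 log units; beyond the scatter). A ring at this position therefore did not by itself restore the number of compound 1, while the open 1-ethoxyethyl of compound 2, with the same heavy-atom and hydrogen-bond-acceptor counts as oxolan-3-yl, stayed much nearer to it. Nothing available here accounts for this gap. The compounds shown leave open whether a cyclopentyl group, an oxan-4-yl group or a longer ether chain would stand nearer compound 1 or compound 3.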